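This account rests on a few compounds, and the source may have more. Where it says the series, first, only, none or still open, it means among the compounds named here.

The compounds measured in an assay for inhibition of Fatty-acid amide hydrolase 1 (Rattus norvegicus) (on this read-out lower numbers stand for stronger inhibition and higher numbers for weaker inhibition), so far:

Compound 1, `NC(=O)c1ccc(-c2cnc(C(O)CCc3ccc(-c4ccccc4)cc3)o2)nc1`: compound 1 gives > 1000 nM, which is a limit of the assay and not a number.
Compound 2, `O=C(CCc1ccc(-c2ccccc2)cc1)c1ncc(-c2ccncc2)o1`: compound 2 gives 2.3 nM.
Compound 3, `CN(C)C(=O)c1cnc(C(=O)CCc2ccc(Oc3ccccc3)cc2)o1`: compound 3 gives 5.4 nM.

Among the two numbers, compound 2 has the lowest value; the nearest is compound 3, which lies above it by a step beyond the usual scatter. Compound 1 sits at the limit of the assay (the limit of > 1000 nM in this assay, at which 1 of the 3 values shown sits), so its standing against the other two cannot be placed more closely than that.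

Compound 4, `COC(=O)c1cc(-c2cnc(C(=O)CCc3ccc(-c4ccccc4)cc3)o2)ccn1`, has not yet been measured. It differs from compound 2 in one place: methoxycarbonyl in place of hydrogen on an aromatic carbon. In words, methoxycarbonyl stands in place of hydrogen on an aromatic carbon, next to the ring nitrogen and meta to a large group; cut one bond further out, pyridin-4-yl becomes 2-(methoxycarbonyl)pyridin-4-yl.

Among the measured compounds shown here, no measured pair shows this change, so the size of the step can only be estimated. The carbonyl linker that compound 2 shares with compound 3 is kept in compound 4, and both of those compounds give low numbers, so compound 4 is expected to stay in that low range. The step from compound 2 to compound 4 is expected to be a 2.2-fold higher number from compound 2 to compound 4 (0.34 log units; beyond the scatter), a change that may not exceed the scatter. Compound 4 is estimated at 5 nM, with a range from 1.5 nM to 20 nM.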

Compound 4, inhibition constant: 1.5 nM
Compound 4: middle estimate off by 3.3-fold (0.52 log units), on the high side, and the stated range covers the measured number.
By their numbers in this assay, from the lowest: compounds 4 and 2 (each within the scatter of the next); then compound 3. At a limit, above all of these: compound 1.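

In this assay, methoxycarbonyl in place of hydrogen on an aromatic carbon, next to the ring nitrogen and meta to a large group, gives a 1.5-fold lower number from compound 2 to compound 4 (0.19 log units; within the scatter), so the two compounds cannot be told apart on this read-out. Before this result, compound 2 was the only compound with the pyridin-4-yl group, and it carried only hydrogen at this position, so nothing showed what a larger group there would do. Compound 4 now shows that a group of 4 heavy atoms, with 2 hydrogen-bond acceptors, can stand on this carbon and the number remains low, although nothing shown bears on the cause of this result.

From the compounds shown here alone, whether this low range also holds for a carboxylic acid, a primary amide or an aminomethyl group on the same carbon remains open. Going by these compounds, it is also open whether an ethyl ester, a longer chain on the ester oxygen, or methoxycarbonyl on another carbon of the ring would give a number close to those of compound 2 and compound 4.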